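The source may report more compounds than this note shows. Statements on the series, on what has been measured and on what is new or still open speak of the compounds shown alone.

Going by the values given here, in a functional assay on NCI60 cells (Homo sapiens) for inhibition (a higher number here means a weaker inhibitor of growth, a lower number a stronger inhibitor of growth), compound 2 (`NC(=O)c1cc(I)ccc1NC(=O)COc1ccccc1`) gives 35500 nM, the lower of the two numbers so far, while compound 1 (`NC(=O)c1cc(Cl)ccc1NC(=O)COc1ccccc1`) gives 72400 nM. Compound 3 (`COc1ccc(NC(=O)COc2ccccc2)c(C(N)=O)c1`) has methoxy in place of iodo on an aromatic carbon, meta to a carbamoyl group and para to a large group: methoxy in place of iodo on an aromatic carbon. Among the compounds with values here, only one measured step bears on this change: a 2.0-fold lower number from compound 1 to compound 2 (0.31 log units; beyond the scatter), a modest step with iodo in place of chloro. Within the data shown here, no methoxy compound has been measured, so this step offers only a rough scale. On that basis, removing the iodo is expected to give a modest rise in the number in this assay, towards the level of compound 1 at 72400 nM. The expected step is a 1.8-fold higher number from compound 2 to compound 3 (0.26 log units; within the scatter). For compound 3 the estimated value is 65000 nM, with an expected range of 35000 nM to 100000 nM.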

Compound 3, concentration for total growth inhibition: 49000 nM
The estimate for compound 3 lay 1.3-fold (0.12 log units) above the measured number; the range from low to high includes it.
By their numbers in this assay, from the lowest: compounds 2, 3 and 1 (each within the scatter of the next, the first and the last beyond it).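

At this position, meta to a carbamoyl group and para to a large group, this assay now has a substituent other than a halogen to read. Methoxy in place of iodo (a 1.4-fold higher number from compound 2 to compound 3 (0.14 log units; within the scatter)) and methoxy in place of chloro (a 1.5-fold lower number from compound 1 to compound 3 (0.17 log units; within the scatter)) both stay within the scatter, so methoxy cannot be told apart from either halogen, although the two halogens themselves are separated (a 2.0-fold lower number from compound 1 to compound 2 (0.31 log units; beyond the scatter)). Nothing available accounts for these numbers.

Still open, on these data alone, is whether an amine or a carboxylic acid at this position, or a longer chain such as ethoxy or propoxy in place of methoxy, would move the number beyond the scatter. Also open, as far as these compounds go, is how the parent with plain hydrogen here would compare with these three compounds.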